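Ethylcarbamoyl in Place of Methoxycarbonyl on a Shared Core

The source may report more compounds than this note shows. Statements on the series, on what has been measured and on what is new or still open speak of the compounds shown alone.

Compound 2 `COC(=O)NC1=CS(=O)(=O)O[C@@]12[C@@H](CO[Si](C)(C)C(C)(C)C)O[C@@H](n1cc(C)c(=O)n(C)c1=O)[C@@H]2O[Si](C)(C)C(C)(C)C` is known in a functional assay on HEL cells (Homo sapiens) (a higher number here means that more compound is tolerated, a lower number that less compound is tolerated), only as a limit, > 200000 nM; it sits at the limit of > 200000 nM in this assay, at which 1 of the 3 values shown sits. Compound 1 `COC(=O)CNC1=CS(=O)(=O)O[C@@]12[C@@H](CO[Si](C)(C)C(C)(C)C)O[C@@H](n1cc(C)c(=O)n(C)c1=O)[C@@H]2O[Si](C)(C)C(C)(C)C` gives 160000 nM in this assay, and compound 3 `Cc1cn([C@@H]2O[C@H](CO[Si](C)(C)C(C)(C)C)[C@@]3(OS(=O)(=O)C=C3NCC(=O)C(=O)O)[C@H]2O[Si](C)(C)C(C)(C)C)c(=O)n(C)c1=O` gives 146000 nM. The measured steps are small: an at least 1.2-fold higher number from compound 1 to compound 2 (0.09 log units; that floor lies within the scatter), a 1.1-fold lower number from compound 1 to compound 3 (0.04 log units; within the scatter) and an at least 1.3-fold lower number from compound 2 to compound 3 (0.13 log units; that floor lies within the scatter). Compound 4 `CCNC(=O)NC1=CS(=O)(=O)O[C@@]12[C@@H](CO[Si](C)(C)C(C)(C)C)O[C@@H](n1cc(C)c(=O)n(C)c1=O)[C@@H]2O[Si](C)(C)C(C)(C)C` differs from compound 2 by ethylamino in place of methoxy on a carbonyl carbon. Only a 1.1-fold lower number from compound 1 to compound 3 (0.04 log units; within the scatter) touches the group on a carbonyl carbon, and it stays within the scatter; the other two steps alter the amine nitrogen and also stay within the scatter. One therefore expects no step beyond the scatter, a number no higher from compound 2 to compound 4 (the limit leaves the size open), and compound 4 is expected to give 200000 nM, between 110000 nM and 400000 nM.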

Compound 4, half-maximal cytotoxic concentration: 10000 nM
Compound 4: middle estimate off by 20-fold (1.30 log units), on the high side; measured number outside the range, below it.
By their numbers in this assay, from the lowest: compound 4; then compounds 3 and 1 (each within the scatter of the next). At a limit, above all of these: compound 2.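

In this assay, within the data shown here, ethylamino in place of methoxy on a carbonyl carbon brings an at least 20-fold lower number from compound 2 to compound 4 (1.30 log units; beyond the scatter), so this position responds to a change that the earlier steps did not reveal. The ethylcarbamoyl group also stands apart from the other groups on the amine nitrogen, with a 15-fold lower number from compound 3 to compound 4 (1.16 log units; beyond the scatter) and a 16-fold lower number from compound 1 to compound 4 (1.20 log units; beyond the scatter). Compound 2 is known only as a limit, so its step is a floor: the limit of > 200000 nM in this assay, at which 1 of the 4 values shown sits.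

The compounds shown leave open whether the change follows the nitrogen or the ethyl chain. A methylamino group, a longer chain on that nitrogen or an unsubstituted amino group on the carbonyl carbon could separate the two.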